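A Larger Group on the Core of Compound 1

The source may hold more compounds than are shown below. What is called first, only, known or untested is meant among the compounds shown, and "the series" means these compounds.

Among the measured compounds shown here, three related compounds have numbers so far in a physicochemical assay for lipophilicity, using the shake flask method, measured as octanol-water partition, at pH 7.4 (on this read-out higher numbers stand for higher lipophilicity and lower numbers for lower lipophilicity), and compound 1 (`CC(=O)N[C@@H]1CCC[C@H](C(=O)Nc2cc(-c3cnc4n3CCC4)c(Cl)cn2)C1`) is the lowest of them at 2.6 on this scale. Compound 3 (`CC(=O)N[C@@H]1CCC[C@H](C(=O)Nc2cc(-c3cnn4c3CC(C)(C)C4)c(C)cn2)C1`) gives 3.1 and compound 2 (`CC(=O)N[C@@H]1CCC[C@H](C(=O)Nc2cc(-c3cnn4c3CC(C)(C)CC4)c(F)cn2)C1`) gives 3.6 as its reading. Both lie above compound 1 by more than the scatter.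

Compound 4 (`CC(=O)N[C@@H]1CCC[C@H](C(=O)Nc2cc(-c3cnc4n3CC(C)(C)C4)c(Cl)cn2)C1`) has not yet been measured. It departs from compound 1 in one place: a group of 10 heavy atoms (8 carbon, 2 nitrogen; one five-membered non-aromatic ring with 1 hetero atom, one five-membered aromatic ring with 2 hetero atoms) in place of a group of 8 heavy atoms (6 carbon, 2 nitrogen; one five-membered non-aromatic ring with 1 hetero atom, one five-membered aromatic ring with 2 hetero atoms), on an aromatic carbon (the site is ortho to a chloro group and opposite the ring nitrogen).

For the measured compounds named here, no two measured compounds differ in one place only, so no measured step shows this change directly. Compound 2 and compound 3 each differ from compound 1 in more than one place and offer only a rough guide. The entering group differs from the leaving group by carbon alone, and a rise beyond the scatter is expected in this assay for this change. That expectation leans on compound 3 with its 3.1 as the nearest higher number. The estimated move is a number 0.60 log units higher from compound 1 to compound 4 (beyond the scatter) in the upward direction. For compound 4 the estimated value is 3.2 with an expected range from 2.9 to 3.6 for now.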

Compound 4, distribution coefficient: 3.6
Beside the measured number, compound 4's estimate is 0.40 log units below it, and the stated range covers the measured number.
By their numbers in this assay, from the lowest: compound 1; then compound 3; then compounds 2 and 4 (each within the scatter of the next).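

With compound 4 the account gains its first comparison of two compounds that differ in one place, and in this assay the exchange on an aromatic carbon, opposite the ring nitrogen, gives a number 1.00 log units higher from compound 1 to compound 4 (beyond the scatter) for a change of carbon alone. The entering and leaving groups have the same rings and the same counts of hydrogen-bond donors and acceptors, so this position is now shown to respond to added carbon in the group, which compound 2 and compound 3 could not show, as each differs from compound 1 in more than one place. Nothing measured here explains the size of this step.

The compounds shown leave open how this assay would read if the five-membered non-aromatic ring carried a hydroxyl group or an amine instead of the added carbon. They also leave open whether the same exchange would give a step of similar size with a fluoro group in place of the chloro group, with all else in the molecule kept as it is.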